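A few compounds are considered here, and "the series" means these few. Any claim that something is new, unique, unknown or untested is made for them only; others in the source may bear on it.

Working notes on the series.

Of the compounds shown here, three on a shared core have been measured in an assay on Sf9 cells for inhibition of serine/threonine-protein kinase 4 (Homo sapiens), read by luminescence and ADP-Glo, with a stated time of 1 h, in the presence of a further agent that is not named here; a lower number here means a stronger inhibitor, a higher number a weaker inhibitor. Compound 1 `CC1C(=O)N(C)c2cnc(Nc3ccc(S(N)(=O)=O)cc3)nc2N1C` gives 313 nM. Compound 2 `CN1C(=O)C(CC2CC2)N(C)c2nc(Nc3ccc(S(N)(=O)=O)cc3)ncc21` gives 211 nM. Compound 3 `COc1ccccc1C1C(=O)N(C)c2cnc(Nc3ccc(S(N)(=O)=O)cc3)nc2N1C` gives 251 nM. Compound 3 sits second highest of the three numbers; its nearest neighbour is compound 2 and its furthest is compound 1, and both gaps are within the scatter, so no order among the three can be read.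

Compound 4 `CN1C(=O)C(c2c(F)cccc2F)N(C)c2nc(Nc3ccc(S(N)(=O)=O)cc3)ncc21` is not yet measured. The change is 2,6-difluorophenyl in place of 2-methoxyphenyl on a saturated ring carbon. Going by the values given here, the steps that bear on this position are a 1.2-fold lower number from compound 1 to compound 3 (0.10 log units; within the scatter) and a 1.2-fold higher number from compound 2 to compound 3 (0.08 log units; within the scatter), both within the scatter, so methyl, cyclopropylmethyl and 2-methoxyphenyl on this saturated ring carbon all give numbers of the same size. Among the compounds with values here, no measured step tests a 2,6-difluorophenyl here, nor any group of this kind with no hydrogen-bond acceptor.

On this basis no step beyond the scatter is expected in this assay. Compound 4 is expected to give 250 nM, with a range from 100 nM to 650 nM. For compound 4 this estimate implies a 1.0-fold lower number from compound 3 to compound 4 (0.00 log units; within the scatter).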

Compound 4, half-maximal inhibitory concentration: 42 nM
Beside the measured number, compound 4's estimate is 6.0-fold (0.77 log units) above it; measured number below the stated range.
By their numbers in this assay, from the lowest: compound 4; then compounds 2, 3 and 1 (each within the scatter of the next).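

In this assay, going by these compounds alone, this saturated ring carbon is not indifferent to its substituent: 2,6-difluorophenyl gives the first steps here beyond the scatter, namely a 6.0-fold lower number from compound 3 to compound 4 (0.78 log units; beyond the scatter) as well as a 5.0-fold lower number from compound 2 to compound 4 (0.70 log units; beyond the scatter) and a 7.5-fold lower number from compound 1 to compound 4 (0.87 log units; beyond the scatter) as the other two comparisons. Since 2-methoxyphenyl and 2,6-difluorophenyl both carry one six-membered aromatic ring of carbon only and the same heavy-atom count, an aromatic ring at this carbon does not by itself set the number, and the step goes with the exchange of substituents on that ring. Nothing available here explains the origin of this step.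

Still open, as far as these compounds go, is whether unsubstituted phenyl, 2-fluorophenyl or 2,6-dichlorophenyl at this carbon gives a number of the same size as 2,6-difluorophenyl. Also open, from the compounds shown here alone, is how a phenyl ring bearing an amine or a carboxylic acid would read here.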